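This account rests on a few compounds, and the source may have more. Where it says the series, first, only, none or still open, it means among the compounds named here.

Working notes on the series.

Compound 1 `COc1cccc(/C=C/C(=O)Nc2cc(C(=O)c3cc(OC)c(OC)c(OC)c3)ccc2OC)c1` and compound 2 `COc1cccc(/C=C/C(=O)Nc2cc(C(=O)c3cc(OC)c(OC)c(OC)c3)cc(OC)c2OC)c1` share one core and differ only in a methoxy in place of hydrogen on an aromatic carbon. In a functional assay on ME-180 cells (Homo sapiens) for cytotoxicity, read by MTT assay, with a stated time of 72 h (a higher number here means a weaker inhibitor, a lower number a stronger inhibitor), compound 1 gives 4300 nM, and compound 2 gives 8600 nM. That single step, a 2.0-fold higher number from compound 1 to compound 2 (0.30 log units; within the scatter), sits within the scatter, so the two numbers cannot be ordered. For the measured compounds named here, compound 2 stands as the higher of the two values recorded so far, with compound 1 its only neighbour.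

Compound 3 `COc1cc(C(=O)c2cc(OC)c(OC)c(OC)c2)cc(NC(=O)/C=C/c2ccc(C(F)(F)F)cc2)c1OC` keeps the core of compound 2 and changes the cinnamoyl end: 4-(trifluoromethyl)phenyl in place of 3-methoxyphenyl on a double-bonded chain carbon bound to a double-bonded chain carbon. Going by the values given here, no measured step concerns this end of the molecule; the only step in hand, from compound 1 to compound 2, changes the central ring and says nothing about the aryl on the double-bonded chain. Without any comparable step, no direction beyond the scatter is expected for compound 3 in this assay, and the expected step is a 1.1-fold lower number from compound 2 to compound 3 (0.03 log units; within the scatter). From the compounds shown here alone, the estimate for compound 3 in this assay is therefore 8000 nM, with a range from 2500 nM to 25000 nM, kept wide because the change is untested.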

Compound 3, half-maximal inhibitory concentration: 3600 nM
Estimate against measurement, compound 3: 2.2-fold (0.35 log units) above; the range from low to high includes it.
By their numbers in this assay, from the lowest: compounds 3, 1 and 2 (each within the scatter of the next, the first and the last beyond it).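

For the compounds shown here, on a double-bonded chain carbon bound to a double-bonded chain carbon, 4-(trifluoromethyl)phenyl in place of 3-methoxyphenyl gives a 2.4-fold lower number from compound 2 to compound 3 (0.38 log units; beyond the scatter) in this assay, so this end of the molecule supplies the first single change that lies beyond the scatter, though only modestly, whereas the methoxy change on the shared core, a 2.0-fold higher number from compound 1 to compound 2 (0.30 log units; within the scatter), does not. The step replaces both the substituent and its printed place on the phenyl, so the single result cannot be assigned to trifluoromethyl alone or to the loss of the 3-methoxy group alone. No measurement in hand bears on what lies behind this step.

Open, from the compounds shown here alone, is whether 3-(trifluoromethyl)phenyl or 4-methoxyphenyl at the same place would separate the identity of the substituent from its location, and whether a phenyl carrying a nitrile or an amine would follow the same direction. Also open is whether 4-(trifluoromethyl)phenyl gives a step of similar size on the core of compound 1, since the compounds shown test it only on the core of compound 2.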